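The compounds below may be only part of what the source reports. "The series", "measured", "known", "first", "only" and "open" are said of these compounds alone.

Three analogues share one core and differ only in the group standing ortho to the methylsulfonyl group. Compound 1, `Cc1cc(F)c(S(C)(=O)=O)cc1C(=O)N=C(N)N`, carries a fluoro there and gives 44 nM in a functional assay for inhibition of sodium/hydrogen exchanger (Oryctolagus cuniculus); on this read-out lower numbers stand for stronger inhibition and higher numbers for weaker inhibition. Compound 2, `CCCCCc1cc(C)c(C(=O)N=C(N)N)cc1S(C)(=O)=O`, carries a pentyl and gives 27 nM. Compound 3, `Cc1cc(C2CCC2)c(S(C)(=O)=O)cc1C(=O)N=C(N)N`, carries a cyclobutyl and gives 8.2 nM. The step of a 1.6-fold lower number from compound 1 to compound 2 (0.21 log units; within the scatter) is small, whereas a 5.4-fold lower number from compound 1 to compound 3 (0.73 log units; beyond the scatter) and a 3.3-fold lower number from compound 2 to compound 3 (0.52 log units; beyond the scatter) both go beyond the scatter, so compound 3 stands with the lowest number of the three, beyond the scatter from each of the other two.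

Compound 4, `Cc1cc(C2CCCCC2)c(S(C)(=O)=O)cc1C(=O)N=C(N)N`, follows from compound 3 by a single change: cyclohexyl in place of cyclobutyl on an aromatic carbon. Within the data shown here, two measured steps bear on it. The step from a fluoro to a cyclobutyl, a 5.4-fold lower number from compound 1 to compound 3 (0.73 log units; beyond the scatter), shows that a ring in this position gives a lower number than the small fluoro; the step of a 3.3-fold lower number from compound 2 to compound 3 (0.52 log units; beyond the scatter) shows that a chain of five carbons in the same place gives a higher number than the four-membered ring. A six-membered ring sits between those two cases in its count of carbons, so for compound 4 the step of a 1.6-fold higher number from compound 3 to compound 4 (0.20 log units; within the scatter) is expected to stay near or slightly above compound 3, within the scatter. Compound 4 is therefore estimated at 13 nM, with a range of 4 nM to 40 nM.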

Compound 4, half-maximal inhibitory concentration: 22 nM
Estimate against measurement, compound 4: 1.7-fold (0.23 log units) below; measured number inside the range.
By their numbers in this assay, from the lowest: compound 3; then compounds 4, 2 and 1 (each within the scatter of the next).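

In this assay, the size of the ring at this position matters: cyclohexyl in place of cyclobutyl gives a 2.7-fold higher number from compound 3 to compound 4 (0.43 log units; beyond the scatter), a step beyond the scatter. The earlier compounds set cyclobutyl apart from both fluoro and pentyl, but the new result shows that a carbon ring as such does not carry that advantage, since cyclohexyl in place of pentyl gives a 1.2-fold lower number from compound 2 to compound 4 (0.09 log units; within the scatter) and cyclohexyl in place of fluoro gives a 2.0-fold lower number from compound 1 to compound 4 (0.30 log units; within the scatter), both within the scatter; among these four groups, only cyclobutyl stands apart. Nothing available explains why the larger ring loses the advantage of the smaller one.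

The compounds shown leave open whether cyclopentyl would fall nearer cyclobutyl or cyclohexyl, and whether cyclopropyl would give a lower number than cyclobutyl or a higher one. They also leave open how a ring holding a heteroatom, such as piperidinyl or tetrahydropyranyl, would compare with cyclohexyl at this position, and whether a branched chain such as isopropyl would follow pentyl or cyclobutyl.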